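The source may hold more compounds than are shown below. What is called first, only, known or untested is meant among the compounds shown, and "the series" means these compounds.

Measured so far:
Compound 1, `O=C(/C=C/c1ccc([N+](=O)[O-])cc1)c1ccc(O)c(O)c1`: 8200 nM
Compound 2, `Nc1ccc(C(=O)/C=C/c2ccco2)cc1`: 28000 nM

In a functional assay on HT-29 cells (Homo sapiens) for cytotoxicity, read by resazurin assay, with a stated time of 48 h (on this read-out lower numbers stand for an effect already at smaller amounts and higher numbers for an effect only at larger amounts of compound), compound 2 gives the higher of the two numbers, and its gap to compound 1 lies beyond the scatter. Compound 3, `O=C(/C=C/c1ccco1)c1ccc(NC(=O)c2cccs2)cc1`, has not been measured. It differs from compound 2 by (thiophen-2-yl)carbonyl in place of hydrogen on a nitrogen on an aromatic ring. Among the compounds with values here, no measured pair shows this change, so its effect is unknown. A small step, if any, toward lower numbers is expected, a 1.9-fold lower number from compound 2 to compound 3 (0.27 log units; within the scatter). Compound 3 is estimated at 15000 nM, within a range from 4000 nM to 60000 nM.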

Compound 3, half-maximal effective concentration: 50000 nM
Compound 3: the middle estimate sits 3.3-fold (0.52 log units) below what was measured; the range from low to high includes it.
By their numbers in this assay, from the lowest: compound 1; then compounds 2 and 3 (each within the scatter of the next).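

With (thiophen-2-yl)carbonyl in place of hydrogen on a nitrogen on an aromatic ring, this assay shows a 1.8-fold higher number from compound 2 to compound 3 (0.25 log units; within the scatter) and so no difference that stands clear of the scatter. Within the data shown here, this is the first sign that, in this series, the hydrogen on that nitrogen can be replaced without a clear shift in the read-out. Nothing available bears on the reason for this result. As far as these compounds go, whether an acetyl group or a methyl group on the same nitrogen would read alike stays open, and so does whether this replacement would behave the same way on the core of compound 1.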